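Aryl swap from compound 3 to compound 4

A few compounds are considered here, and "the series" means these few. Any claim that something is new, unique, unknown or untested is made for them only; others in the source may bear on it.

Measured so far in a functional assay on GBM2 cells (Homo sapiens) for antiproliferative activity, read by WST assay, with a stated time of 72 h (on this read-out lower numbers stand for stronger inhibition and higher numbers for weaker inhibition), for this series:
- compound 1 `O=C(Nc1cccc(F)c1)Nc1cc2ncncc2cc1OCc1ccccc1Cl` gives 3200 nM here
- compound 2 `O=C(Nc1cccc(Cl)c1)Nc1cc2ncncc2cc1OCc1cccc(Cl)c1` gives 3500 nM here
- compound 3 `O=C(Nc1ccc(C(F)(F)F)cc1)Nc1cc2ncncc2cc1OCc1cccc(Cl)c1` gives 4700 nM here

Compound 3 at 4700 nM lies within the scatter of both compound 2 and compound 1. Compound 4 `O=C(Nc1cccc(F)c1)Nc1cc2ncncc2cc1OCc1cccc(Cl)c1` is not yet measured, and it differs from compound 3 as follows: 3-fluorophenyl in place of 4-(trifluoromethyl)phenyl on an amide-type nitrogen on the same shared core. Among the compounds with values here, the one measured step on this nitrogen is a 1.3-fold higher number from compound 2 to compound 3 (0.13 log units; within the scatter) and it also involves 4-(trifluoromethyl)phenyl. Compound 1 carries 3-fluorophenyl and gives 3200 nM in this assay with its other substituent differing. No step beyond the scatter is therefore expected, and the expected step is a 1.3-fold lower number from compound 3 to compound 4 (0.13 log units; within the scatter) in either reading. Compound 4 is estimated at 3500 nM with an expected range of 2000 nM to 6000 nM for now.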

Compound 4, half-maximal inhibitory concentration: 7800 nM
The estimate for compound 4 lay 2.2-fold (0.35 log units) below the measured number, and the stated range ends below it.
By their numbers in this assay, from the lowest: compounds 1, 2, 3 and 4 (each within the scatter of the next, the first and the last beyond it).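

In this assay, the step on the amide-type nitrogen from 4-(trifluoromethyl)phenyl to 3-fluorophenyl stays within the scatter (a 1.7-fold higher number from compound 3 to compound 4 (0.22 log units; within the scatter)), while fluoro in place of chloro on an aromatic carbon gives a modest step beyond it (a 2.2-fold higher number from compound 2 to compound 4 (0.35 log units; beyond the scatter)). The other side of the core also responds: 3-chlorophenyl in place of 2-chlorophenyl gives a modest step beyond the scatter (a 2.4-fold higher number from compound 1 to compound 4 (0.39 log units; beyond the scatter)). No evidence is available on the origin of these steps. All four compounds carry chloro, fluoro or trifluoromethyl on the phenyl at the amide-type nitrogen. As far as these compounds go, the effect of an amine or a carboxylic acid on that ring remains open.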